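Swapping the sugar for a carbocycle on a purine nucleoside

The source may report more compounds than this note shows. Statements on the series, on what has been measured and on what is new or still open speak of the compounds shown alone.

Measured so far:
compound 1, `O[C@@H]1[C@H](O)[C@@H]2C[C@@H]2[C@H]1n1cnc2c(NCC(C3CC3)C3CC3)nc(Cl)nc21`: 10000 nM
compound 2, `CC(C)(C)[C@H](Nc1nc(Cl)nc2c1ncn2[C@H]1[C@H](O)[C@H](O)[C@]2(CO)C[C@H]12)C1CC1`: > 100000 nM
compound 3, `OC[C@H]1O[C@@H](n2cnc3c(NC(C4CCC4)C4CCC4)nc(Cl)nc32)[C@H](O)[C@@H]1O`: 27000 nM

In an ADME assay on Vero 76 cells (Chlorocebus sabaeus) for cytotoxicity, read by neutral red uptake (a higher number here means that more compound is tolerated, a lower number that less compound is tolerated), compound 3 gives the highest of the two numbers shown. Its nearest neighbour is compound 1, which sits a clear distance lower in this assay, beyond the scatter. Compound 2 does not give a number in this assay but only a limit, (the limit of > 100000 nM in this assay, at which 1 of the 3 values shown sits).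

The piece follows the step to compound 4, `O[C@@H]1[C@H](O)[C@@H]2C[C@@H]2[C@H]1n1cnc2c(NC(C3CCC3)C3CCC3)nc(Cl)nc21`, which has not yet been measured in this assay. Compound 4 differs from compound 3 in one place: a group of 8 heavy atoms (6 carbon, 2 oxygen; one three-membered non-aromatic ring of carbon only, one five-membered non-aromatic ring of carbon only) in place of a group of 9 heavy atoms (5 carbon, 4 oxygen; one five-membered non-aromatic ring with 1 hetero atom), on an aromatic nitrogen. The group that enters in compound 4 is the same group that compound 1 carries on its aromatic nitrogen, so the value of compound 1, 10000 nM, is the closest guide available among the measured compounds.

On that basis the step of a 2.1-fold lower number from compound 3 to compound 4 (0.32 log units; beyond the scatter) is expected to run downward, of modest size, though it may well fall within the scatter. Compound 4 is therefore estimated at 13000 nM, with a range from 4500 nM to 40000 nM in this assay.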

Compound 4, half-maximal cytotoxic concentration: 17000 nM
Estimate against measurement, compound 4: 1.3-fold (0.12 log units) below; low and high end bracket the measured number.
By their numbers in this assay, from the lowest: compounds 1, 4 and 3 (each within the scatter of the next, the first and the last beyond it). At a limit, above all of these: compound 2.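

Among the compounds shown here, with a 1.6-fold lower number from compound 3 to compound 4 (0.20 log units; within the scatter) in this assay, exchanging the 3,4-dihydroxy-5-(hydroxymethyl)oxolan-2-yl group for the carbocycle on the aromatic nitrogen gives the first single change that can be read at this position, and it does not move the number beyond the scatter. Likewise, a 1.7-fold higher number from compound 1 to compound 4 (0.23 log units; within the scatter) means that dicyclobutylmethyl in place of 2,2-dicyclopropylethyl on the nitrogen does not separate the two compounds either. Nothing shown accounts for either step.

Going by these compounds, whether the carbocycle exchange stays this small with another group on that nitrogen, such as a benzyl group or a chain ending in an amine, remains open. Compound 2 carries a hydroxymethyl on its carbocycle but differs from compound 4 in more than one place, and it gives only a limit: the limit of > 100000 nM in this assay, at which 1 of the 4 values shown sits.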